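The source may hold more compounds than are shown below. What is called first, only, known or untested is meant among the compounds shown, and "the series" means these compounds.

Compound 1 `COc1ccc(C(=O)Nc2ccccc2Cl)cc1OC1CCCC1` gives 190 nM in an assay on isolated protein for inhibition of phosphodiesterase 4A (Sus scrofa); a lower number here means a stronger inhibitor, a higher number a weaker inhibitor. Compound 2 `COc1ccc(C(=O)Nc2ccccc2Cl)cc1OC` gives 650 nM in this assay. Going by the values given here, the single step in hand, a 3.4-fold higher number from compound 1 to compound 2 (0.53 log units; beyond the scatter), is beyond the scatter, so compound 2 stands at the higher of the two numbers so far. The next step goes to compound 3 `COc1ccc(C(=O)Nc2ccccc2Cl)cc1OC(=O)C1CCCC1`, with cyclopentylcarbonyl in place of methyl on an oxygen on an aromatic ring. Among the compounds with values here, the only measured step that bears on it is the swap between the small group and the five-membered ring on the same oxygen, a 3.4-fold higher number from compound 1 to compound 2 (0.53 log units; beyond the scatter); it speaks for a lower number when the ring returns, but the entering group carries a carbonyl that no measured compound has, so that step is a loose guide only. The expected step from compound 2 to compound 3 is a 2.2-fold lower number from compound 2 to compound 3 (0.34 log units; beyond the scatter), toward a lower number. Compound 3 is estimated at 300 nM, with a range from 90 nM to 1000 nM.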

Compound 3, half-maximal inhibitory concentration: > 1000000 nM
Compound 3 gave a limit, no number; the forecaster's own chance of this, stated with the estimate: 5%; at least 3300-fold (3.52 log units) between middle value and limit.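

In this assay compound 3 reads as a limit and not as a number: the limit of > 1000000 nM in this assay, at which 1 of the 3 values shown sits.

On an oxygen on an aromatic ring, the change from methyl to cyclopentylcarbonyl gives an at least 1500-fold higher number from compound 2 to compound 3 (3.18 log units; beyond the scatter), far larger than the earlier modest step, a 3.4-fold higher number from compound 1 to compound 2 (0.53 log units; beyond the scatter). Adding the carbonyl while keeping the five-membered ring gives an at least 5200-fold higher number from compound 1 to compound 3 (3.72 log units; beyond the scatter), so the ring alone does not keep the number low, and in these compounds the large loss goes with the carbonyl on this oxygen.

On these data alone, whether a small acetyl on the same oxygen tracks with cyclopentylcarbonyl or with methyl remains open, which leaves the part played by the ring in the loss unsettled. Also open, as far as these compounds go, is whether a cyclohexyl or a longer alkyl chain on this oxygen, without a carbonyl, would give a lower number than compound 1.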